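Three Ureas Barely Move the Kinase Melting Point

This account rests on a few compounds, and the source may have more. Where it says the series, first, only, none or still open, it means among the compounds named here.

Compound 1, `CC(C)(C)c1cc(NC(=O)Nc2cc(C(F)(F)F)cc(C(F)(F)F)c2)n(-c2ccccc2)n1`: -0.5 degrees C
Compound 2, `Cc1cc(C)cc(NC(=O)Nc2cc(C(C)(C)C)nn2-c2ccccc2)c1`: -0.3 degrees C
Compound 3, `CC(C)(C)c1cc(NC(=O)Nc2ccc(Cl)cc2)n(-c2ccc(C(F)(F)F)cc2)n1`: -0.6 degrees C

All three compounds were tested in an assay on isolated protein for inhibition of serine/threonine-protein kinase 10 (Homo sapiens), read by thermal shift assay, tested at 10 uM; a higher number here means that the compound stabilises the target more against heat, a lower number that the compound stabilises the target less. The three numbers sit close to zero. Compound 3 has the lowest of the three, yet the numbers for compound 1 and compound 2 lie within the scatter of it, so none of the three can be told apart from the others, and none of them shows a clear stabilising effect on the target. No pair of these compounds differs in only one place, so no single structural step among them can be read off.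

Compound 4, `CC(C)(C)c1cc(NC(=O)Nc2ccc(Cl)cc2)n(-c2ccc(C#N)cc2)n1`, has not yet been measured. It differs from compound 3 in one place: cyano in place of trifluoromethyl on an aromatic carbon. Among the measured compounds shown here, the measured compounds give no example of this change, and the three numbers themselves vary only within the scatter, so there is no ground for expecting a shift beyond it. The step from compound 3 to compound 4 is expected to be a number 0.20 degrees C higher from compound 3 to compound 4 (within the scatter), that is, none beyond the scatter. Compound 4 is therefore expected to give about -0.4 degrees C in this assay, with a range from -1.5 degrees C to 0.8 degrees C.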

Compound 4, shift of the target's melting temperature: 2.2 degrees C
Beside the measured number, compound 4's estimate is 2.6 degrees C below it; the whole stated range lies below it.
By their numbers in this assay, from the lowest: compounds 3, 1 and 2 (each within the scatter of the next); then compound 4.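

In this assay, among the compounds shown here, putting cyano in place of trifluoromethyl on an aromatic carbon, para to a large group, gives a number 2.8 degrees C higher from compound 3 to compound 4 (beyond the scatter), the first step in this set that can be read and the first that rises clearly above the scatter. It shows that this position is not indifferent: with the rest of the molecule unchanged, the move from 4-(trifluoromethyl)phenyl to 4-cyanophenyl alone turns a number near zero into real stabilisation of the target against heat. The swap replaces a group of 4 heavy atoms and 0 hydrogen-bond acceptors with one of 2 heavy atoms and 1 hydrogen-bond acceptor, but no measurement here ties the step to either difference or to anything else about the two groups.

On these data alone, it remains open whether the rise is particular to cyano or would also follow from another group at this place, such as an amine, a methoxy group or a carboxylic acid. For the compounds shown here, it also remains open whether cyano would give a similar step on a molecule whose other parts differ, since this single pair is the only example of the change.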